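Fluoro in place of hydrogen: compound 3 to compound 4

The source may hold more compounds than are shown below. What is called first, only, known or untested is meant among the compounds shown, and "the series" means these compounds.

Compound 1 `COc1ccc(-c2ccnc(C(=O)Nc3ccc(Oc4ccnc5cc(OCCCN6CCCCC6)c(OC)cc45)c(F)c3)c2)cc1` gives 690 nM in a functional assay on HT-29 cells (Homo sapiens) for cytotoxicity, read by MTT assay, with a stated time of 72 h; a higher number here means a weaker inhibitor, a lower number a stronger inhibitor. Compound 2 `COc1ccc(-c2ccnc(C(=O)Nc3ccc(Oc4ccnc5cc(OCCCN6CCN(C)CC6)c(OC)cc45)c(F)c3)c2)cc1` gives 390 nM; the one-place step a 1.8-fold lower number from compound 1 to compound 2 (0.25 log units; within the scatter). Compound 3 `COc1cc2c(Oc3ccc(NC(=O)c4cc(-c5ccccc5)ccn4)cc3F)ccnc2cc1OCCCN1CCCC1` gives 120 nM, the lowest of the three numbers, with compound 2 nearest and compound 1 furthest, both gaps beyond the scatter. Compound 4 `COc1cc2c(Oc3ccc(NC(=O)c4cc(-c5ccccc5F)ccn4)cc3F)ccnc2cc1OCCCN1CCCC1` differs from compound 3 by fluoro in place of hydrogen on an aromatic carbon. Within the data shown here, no measured step touches the phenyl of the shared core; the only step known, a 1.8-fold lower number from compound 1 to compound 2 (0.25 log units; within the scatter), concerns the cyclic amine and lies within the scatter, so it sets no direction. For compound 4 the expected step of a 1.1-fold higher number from compound 3 to compound 4 (0.03 log units; within the scatter) is therefore none beyond the scatter. Compound 4 is estimated at 130 nM, with a range of 55 nM to 320 nM.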

Compound 4, half-maximal inhibitory concentration: 230 nM
For compound 4 the middle estimate is 1.8-fold (0.25 log units) below the measured one; the range from low to high includes it.
By their numbers in this assay, from the lowest: compounds 3, 4, 2 and 1 (each within the scatter of the next, the first and the last beyond it).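

Fluoro in place of hydrogen, ortho to a large group on the terminal phenyl of compound 3, gives the only reading at this place in this assay: a 1.9-fold higher number from compound 3 to compound 4 (0.28 log units; within the scatter). Phenyl to 2-fluorophenyl therefore sets no direction at this place, and one fluorine here leaves the number within the scatter. No measured property bears on this result.

Going by these compounds, whether chloro, methyl or a nitrile at this place would move the number beyond the scatter remains open. Also open, on these data alone, is whether 2-fluorophenyl behaves alike with piperidin-1-yl or 4-methylpiperazin-1-yl at the chain end.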